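Methyl Additions on Two Cores: Notes Toward Compound 4

The compounds below may be only part of what the source reports. "The series", "measured", "known", "first", "only" and "open" are said of these compounds alone.

Three compounds have numbers in an assay on HEK293 cells for displacement of a labelled ligand from adenosine receptor A2b (Homo sapiens), with a stated time of 30 min; a lower number here means a stronger inhibitor, a higher number a weaker inhibitor. Compound 1 `CCOC(=O)C1=C(CC)NC(=O)NC1c1ccco1` gives 715 nM. Compound 2 `CCCC1=C(C(=O)OCC)C(c2ccco2)NC(=O)N1` gives 256 nM. Compound 3 `CCOC(=O)C1=C(C)NC(=S)NC1c1ccoc1` gives 43.1 nM, the lowest of the three numbers, its steps to compound 2 and compound 1 both lying beyond the scatter. The difference between the core of compound 1 and the core of compound 3 is not broken down here.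

Compound 2 differs from compound 1 by methyl in place of hydrogen on a saturated chain carbon, two bonds along the chain from a double-bonded ring carbon. For the measured compounds named here, the step of a 2.8-fold lower number from compound 1 to compound 2 (0.45 log units; beyond the scatter) is the only measured step between two compounds that differ in one place.

Compound 4 `CC1=C(C(=O)OC(C)C)C(c2ccoc2)NC(=S)N1` has not yet been measured. It differs from compound 3 by methyl in place of hydrogen on a saturated chain carbon bound to an oxygen next to a carbonyl group and a saturated chain carbon. Going by the values given here, this is the same kind of change as the one from compound 1 to compound 2, a methyl entering for a hydrogen on a saturated chain carbon, but the surroundings differ: in compound 2 that carbon is two bonds along the chain from a double-bonded ring carbon, whereas in compound 4 it is bound to an oxygen next to a carbonyl group and a saturated chain carbon. The measured step thus comes from a different place on a different core, and it is a weak guide for compound 4.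

In this assay the step expected from compound 3 to compound 4 is a 1.1-fold lower number from compound 3 to compound 4 (0.03 log units; within the scatter), within the usual scatter. The number expected for compound 4 is 40 nM, with a range from 12 nM to 130 nM. Among the compounds with values here, this estimate rests mainly on compound 3 giving 43.1 nM, with the direction nudged by the one measured step of a 2.8-fold lower number from compound 1 to compound 2 (0.45 log units; beyond the scatter) only loosely, since it occurred elsewhere.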

Compound 4, inhibition constant: 194 nM
Beside the measured number, compound 4's estimate is 4.9-fold (0.69 log units) below it, and the stated range ends below it.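

Ethoxycarbonyl to isopropoxycarbonyl gives a 4.5-fold higher number from compound 3 to compound 4 (0.65 log units; beyond the scatter), the opposite direction to the earlier methyl addition in this assay, which gave a 2.8-fold lower number from compound 1 to compound 2 (0.45 log units; beyond the scatter). A methyl entering for a hydrogen on a saturated chain carbon therefore has no single direction or size across the two cores in this series: the same change on two cores in this assay, a 2.8-fold lower number (0.45 log units; beyond the scatter) from compound 1 to compound 2 and a 4.5-fold higher number (0.65 log units; beyond the scatter) from compound 3 to compound 4, 13-fold (1.10 log units) apart, beyond the scatter of two such steps This does not show that the core alone sets the outcome, since the two methyls also sit in different places, and with one pair on each core the contributions of core and place cannot be separated.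

Still open, going by these compounds, is what the isopropoxycarbonyl group would do on the core of compound 1, and what the methyl on the chain of compound 2 would do on the core of compound 3; only these crossed pairs would separate core from place. Also open, on these data alone, is how far the trend on the core of compound 3 runs with changes to the ethoxycarbonyl group, whether toward a longer chain such as propoxycarbonyl or toward a carboxylic acid.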